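Sulfonyl swap on the one measured compound

The compounds below may be only part of what the source reports. "The series", "measured", "known", "first", "only" and "open" are said of these compounds alone.

Values in a functional assay on MV4-11 cells (Homo sapiens) for cytotoxicity, read by MTT assay, with a stated time of 72 h; on this read-out higher numbers stand for weaker inhibition and lower numbers for stronger inhibition:
compound 1 `CCOC(=O)c1csc2nc(-c3cccc(NC(=O)c4ccco4)c3)cn12`: > 20000 nM (a limit)
compound 2 `CCOC(=O)c1csc2nc(-c3ccc(NC(=O)CC)cc3)cn12`: 9520 nM
compound 3 `CCOC(=O)c1csc2nc(-c3cccc(NC(=O)CC)c3)cn12`: > 20000 nM (a limit)

For the measured compounds named here, compound 2 gives the only actual number in this set, 9520 nM. The other two entries rest on (the limit of > 20000 nM in this assay, at which 2 of the 3 values shown sit).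

Compound 4 `CCOC(=O)c1csc2nc(-c3ccc(NS(=O)(=O)c4ccc(C)cc4)cc3)cn12` follows from compound 2 by (4-methylphenyl)sulfonyl in place of propanoyl on a nitrogen on an aromatic ring.

Going by the values given here, the only measured step is a step that the two limits leave unreadable from compound 1 to compound 3. It concerns a group on a carbonyl carbon and offers no size to carry over. Among the compounds with values here, no sulfonyl compound has a measured value.

With compound 2 at 9520 nM as the sole anchor, no change beyond the scatter is expected in this assay, in either direction. The expected move is a 1.1-fold lower number from compound 2 to compound 4 (0.02 log units; within the scatter). Compound 4 is estimated at 9000 nM, within a range of 3000 nM to 20000 nM.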

Compound 4, half-maximal inhibitory concentration: > 20000 nM
Compound 4 gave a limit, no number; the forecaster's own chance of this, stated with the estimate: 35%; middle value at least 2.2-fold (0.34 log units) away from the limit.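

In this assay, replacing propanoyl on the nitrogen on an aromatic ring is not neutral: (4-methylphenyl)sulfonyl gives an at least 2.1-fold higher number from compound 2 to compound 4 (0.32 log units; beyond the scatter). For the compounds shown here, this is the first readable step, and it moves away from the only actual number in the set. Compound 4 carries a limit and not a number, so the step has a floor but no measured size: the limit of > 20000 nM in this assay, at which 3 of the 4 values shown sit.

The sulfonyl link and the added aromatic ring enter together in compound 4, and their shares cannot be separated here. A methylsulfonyl or a benzoyl group on this nitrogen would be the separating cases.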